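Cycloheptyl to 3,4-difluorophenyl: a tolerance estimate

A few compounds are considered here, and "the series" means these few. Any claim that something is new, unique, unknown or untested is made for them only; others in the source may bear on it.

Measured in an ADME assay on MT2 cells (Homo sapiens) for cytotoxicity, read by XTT assay, with a stated time of 4 days; a higher number here means that more compound is tolerated, a lower number that less compound is tolerated:
- compound 1 `Cc1ccc(NC(=O)C(=O)NC(c2nc(C)c(CCO)s2)C2CCCCN2)c(F)c1`: > 78800 nM (a limit)
- compound 2 `Cc1nc(C(NC(=O)C(=O)Nc2ccc(F)cc2F)C2CCCCN2)sc1CCO`: > 105000 nM (a limit)
- compound 3 `Cc1nc(C(NC(=O)C(=O)NC2CCCCCC2)C2CCCCN2)sc1CCO`: 60000 nM

Among these results, compound 3 alone has a real number, 60000 nM. Compound 4 `Cc1nc(C(NC(=O)C(=O)Nc2ccc(F)c(F)c2)C2CCCCN2)sc1CCO` differs from it as follows: 3,4-difluorophenyl in place of cycloheptyl on an amide-type nitrogen. Among the measured compounds shown here, two measured steps bear on this swap, and both end at cycloheptyl: an at least 1.3-fold lower number from compound 1 to compound 3 (0.11 log units; that floor lies within the scatter) and an at least 1.7-fold lower number from compound 2 to compound 3 (0.24 log units; that floor lies within the scatter). Run backwards, they suggest that a substituted phenyl group may raise the number in this assay, but each is only a floor within the scatter. A modest rise is therefore expected, possibly none beyond the scatter. The expected change is a 1.5-fold higher number from compound 3 to compound 4 (0.18 log units; within the scatter). Compound 4 is estimated at 90000 nM, with an expected range of 45000 nM to 180000 nM.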

Compound 4, half-maximal cytotoxic concentration: > 78200 nM
Compound 4: only a limit was reported; the forecaster's own chance of this, stated with the estimate: 60%; the middle value is on the limit's open side.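

The swap from cycloheptyl to 3,4-difluorophenyl on this amide-type nitrogen now has its own direct measurement: an at least 1.3-fold higher number from compound 3 to compound 4 (0.11 log units; that floor lies within the scatter). That floor alone does not establish a change beyond the scatter in this assay, but a third substituted phenyl group now gives only a limit. The steps among compounds 1, 2 and 4 cannot be read, as each joins two limits.

Going by these compounds, how far the true value of compound 4 lies past its limit remains open. So does the effect of a carboxylic acid or an amine on the phenyl ring at this position.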